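Chloro in place of methyl on the sulfonyl aryl ring

The source may hold more compounds than are shown below. What is called first, only, known or untested is meant among the compounds shown, and "the series" means these compounds.

Compound 1 `Cc1ccc(-c2nn(-c3ccccc3)cc2-c2nc3ccccc3[nH]2)cc1` and compound 2 `Cc1ccc(-c2nn(-c3ccccc3)cc2-c2nc3ccccc3n2S(=O)(=O)c2ccc(C)cc2)cc1` share the whole core and differ at one aromatic nitrogen, where compound 2 carries a (4-methylphenyl)sulfonyl group in place of hydrogen. In a functional assay on HepG2 cells (Homo sapiens) for antiproliferative activity, read by MTT assay, with a stated time of 24 h (a higher number here means a weaker inhibitor, a lower number a stronger inhibitor), compound 1 gives 6260 nM, and compound 2 gives 520 nM. Within the data shown here, the step of a 12-fold lower number from compound 1 to compound 2 (1.08 log units; beyond the scatter) is the only measured step in the set, so compound 2 holds the lowest of the two numbers, with compound 1 as its sole neighbour, separated by that step.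

Compound 3 `Cc1ccc(-c2nn(-c3ccccc3)cc2-c2nc3ccccc3n2S(=O)(=O)c2ccc(Cl)cc2)cc1` keeps the sulfonyl on the aromatic nitrogen and alters only its aryl ring: chloro in place of methyl on an aromatic carbon. Among the measured compounds shown here, no measured step bears directly on this exchange; the one known step, a 12-fold lower number from compound 1 to compound 2 (1.08 log units; beyond the scatter), concerns the entry of the whole (4-methylphenyl)sulfonyl group, not a swap on its ring. With the sulfonyl retained and one heavy atom exchanged for one heavy atom on the same aromatic carbon, no step beyond the scatter is expected in this assay; the expected step is a 1.0-fold lower number from compound 2 to compound 3 (0.02 log units; within the scatter). Compound 3 is estimated at 500 nM, with an expected range from 200 nM to 1300 nM.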

Compound 3, half-maximal inhibitory concentration: 5520 nM
Compound 3: the middle estimate sits 11-fold (1.04 log units) below what was measured; the whole stated range lies below it.
By their numbers in this assay, from the lowest: compound 2; then compounds 3 and 1 (each within the scatter of the next).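

In this assay the aromatic carbon para to a large group on the sulfonyl aryl ring proves far from neutral: exchanging methyl for chloro, one heavy atom for one heavy atom, gives an 11-fold higher number from compound 2 to compound 3 (1.03 log units; beyond the scatter), a step as large as the one seen when the (4-methylphenyl)sulfonyl group entered. The sulfonyl on the aromatic nitrogen therefore does not by itself bring the lower number, since placing (4-chlorophenyl)sulfonyl on that nitrogen instead of hydrogen gives only a 1.1-fold lower number from compound 1 to compound 3 (0.05 log units; within the scatter), and among the three compounds the gain appears only with the 4-methylphenyl ring of compound 2. Nothing available on these compounds accounts for so sharp a dependence on a single ring substituent.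

The compounds shown leave open whether methyl is singular at this place or whether ethyl, methoxy, an amine or a carboxylic acid on the same carbon would also keep the lower number. They also leave open how an unsubstituted phenylsulfonyl group would read, and whether a carbonyl could stand in for the sulfonyl on the aromatic nitrogen.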